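The compounds below may be only part of what the source reports. "The series", "measured", "known", "first", "only" and "open" are said of these compounds alone.

Working notes on the series. Two compounds carry numbers: compound 1 `COc1ccc2c(c1)CCCN2S(=O)(=O)c1ccc(N2CCCC2=O)cc1` and compound 2 `COc1ccc2c(c1)N(C)CCN2S(=O)(=O)c1ccc(N2CCCC2=O)cc1`, both built on the shared core. In a functional assay on MDA-MB-231 cells (Homo sapiens) for antiproliferative activity, read by fluorescence and SYBR Green assay, with a stated time of 24 h (on this read-out lower numbers stand for stronger inhibition and higher numbers for weaker inhibition), compound 1 gives 20 nM. Compound 2 gives 14 nM in this assay; the two numbers sit within the scatter of each other, and compound 1 holds the highest of the two. The open question is compound 3 `O=C1CCCN1c1ccc(S(=O)(=O)N2CCCc3ccccc32)cc1`, which differs from compound 1 in one place: hydrogen in place of methoxy on an aromatic carbon. Among the compounds with values here, no measured pair in the set isolates this change, so any expectation rests on the two values alone. A small step toward a higher number is expected, possibly no larger than the scatter; the expected step is a 1.8-fold higher number from compound 1 to compound 3 (0.24 log units; within the scatter). Compound 3 is estimated at 35 nM in this assay, with a range from 12 nM to 100 nM.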

Compound 3, half-maximal inhibitory concentration: 15 nM
Beside the measured number, compound 3's estimate is 2.3-fold (0.37 log units) above it; low and high end bracket the measured number.
By their numbers in this assay, from the lowest: compounds 2, 3 and 1 (each within the scatter of the next).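

Hydrogen in place of methoxy on an aromatic carbon gives a 1.3-fold lower number from compound 1 to compound 3 (0.12 log units; within the scatter) in this assay, and this is the first pair in the series that isolates the change. It shows that a number in this range does not depend on the methoxy at this position: compound 3, with a hydrogen atom and no heavy atom there, gives 15 nM in this assay and stays within the scatter of compound 1. Nothing at hand speaks to the reason for this result.

On these data alone, whether the same aromatic carbon accepts other groups remains open, for instance a fluorine atom, a hydroxyl, an amine or a longer alkoxy chain. Also open, as far as these compounds go, is whether hydrogen in place of methoxy gives a step of similar size on the core of compound 2.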